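The compounds below may be only part of what the source reports. "The series", "measured", "known", "first", "only" and "open" are said of these compounds alone.

Of the compounds shown here, two have been read in an ADME assay on PC-12 cells (Rattus norvegicus) for cytotoxicity, read by MTT assay, with a stated time of 24 h; on this read-out lower numbers stand for stronger inhibition and higher numbers for weaker inhibition. In this assay compound 1 (`CCCCc1ccc(-c2nnc(-c3ccc4nc[nH]c4c3)o2)cc1`) gives > 100000 nM, which is a limit and not a number. In this assay compound 2 (`Fc1ccc(-c2nnc(-c3ccc4nc[nH]c4c3)s2)cc1`) gives > 500000 nM, which is also a limit and not a number. Within the data shown here, compound 2 therefore stands on a limit only, and the one other result is a limit as well, so no measured step is available to size a change.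

Compound 3 (`O=[N+]([O-])c1ccc(-c2nnc(-c3ccc4nc[nH]c4c3)s2)cc1`) differs from compound 2 by nitro in place of fluoro on an aromatic carbon, para to a large group: nitro in place of fluoro on an aromatic carbon. In this assay no change beyond the usual scatter is expected, and a further limit is the likeliest report. The expected step is an at least 1.4-fold lower number from compound 2 to compound 3 (0.15 log units; that floor lies within the scatter). This expectation rests only on compound 2 at > 500000 nM, itself a limit, and so it is loose. For compound 3 the estimate is 350000 nM, with an expected range of 100000 nM to 800000 nM.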

Compound 3, half-maximal inhibitory concentration: > 500000 nM
Compound 3 gave a limit, no number; the forecaster's own chance of this, stated with the estimate: 65%; middle value at least 1.4-fold (0.15 log units) from the limit.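

Compound 2 and compound 3 both stand on limits and not numbers in this assay, so the change from fluoro to nitro gives no readable step between them: the limit of > 500000 nM in this assay, at which 2 of the 3 values shown sit.

The compounds shown leave open whether nitro in place of fluoro alters this read-out at all, and at what concentration any of these compounds would give a measured value.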